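The source may hold more compounds than are shown below. What is called first, only, known or untested is meant among the compounds shown, and "the series" means these compounds.

Measured in a functional assay on MCF7 cells (Homo sapiens) for inhibition, read by MTT assay, with a stated time of 72 h; on this read-out higher numbers stand for weaker inhibition and lower numbers for stronger inhibition:
- Compound 1 `CO[C@@H](c1ccccc1)[C@H]1O[C@@H]2CC(=O)O[C@@H]2[C@H]1O`: > 100000 nM
- Compound 2 `CO[C@@H]1[C@H]2OC(=O)C[C@H]2O[C@@H]1[C@H](O)c1ccccc1`: 4040 nM

In this assay, compound 1 gives > 100000 nM, which is a limit of the assay and not a number. Its true value is therefore unknown, and it offers no exact starting point. Compound 2 gives a real number, 4040 nM.

The compound still to be measured is compound 3 `CO[C@H](c1ccccc1)[C@H]1O[C@@H]2CC(=O)O[C@@H]2[C@H]1O`. It has the same atoms and bonds as compound 1, and only one centre is drawn differently: the two compounds have the same atoms and bonds and differ only in configuration as drawn: 1 of 5 stereo elements differ; a stereocentre at a saturated chain carbon is drawn S in compound 1 and R in compound 3. For the measured compounds named here, no measured pair here shows what such a change in configuration does by itself, so any forecast is uncertain. If compound 3 gives a number, the expected direction in this assay is toward stronger inhibition, since compound 1 sits at the limit. Compound 2, at 4040 nM, shows that a compound of this kind can reach a measurable value. Compound 3 could also return only a limit. The estimate amounts to an expected step of an at least 6.6-fold lower number from compound 1 to compound 3 (0.82 log units; beyond the scatter). For compound 3 the estimated value is 15000 nM, with an expected range of 1500 nM to 100000 nM.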

Compound 3, half-maximal inhibitory concentration: > 100000 nM
Compound 3 was reported as a limit; the forecaster's own chance of this, stated with the estimate: 30%; middle value at least 6.6-fold (0.82 log units) from the limit.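

In this assay compound 3 gives > 100000 nM and this is a limit, not a number. For the compounds shown here, compound 1 also sits at a limit, so no step from compound 1 to compound 3 can be read: the limit of > 100000 nM in this assay, at which 2 of the 3 values shown sit.

Going by these compounds, what inverting this one chain carbon does by itself stays open, as does whether compound 1 and compound 3 differ at all.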